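Trading a Naphthalene Amide for a Methoxyphenyl Amide

The source may report more compounds than this note shows. Statements on the series, on what has been measured and on what is new or still open speak of the compounds shown alone.

Compound 1 `Cc1nnc(Sc2cc(NC(=O)c3ccc(Cl)cc3)c3ccccc3c2O)s1`: in a functional assay on HCT-116 cells (Homo sapiens) for antiproliferative activity, read by MTT assay, with a stated time of 48 h (a higher number here means a weaker inhibitor, a lower number a stronger inhibitor), compound 1 gives > 100000 nM, which is a limit of the assay and not a number.
Compound 2 `O=C(Nc1cc(Sc2ncn[nH]2)c(O)c2ccccc12)c1ccc2ccccc2c1`: in this assay compound 2 gives > 100000 nM, again only a limit.
Compound 3 `COc1ccc(/C=C/C(=O)Nc2cc(Sc3ncn[nH]3)c(O)c3ccccc23)cc1OC`: in this assay compound 3 gives > 100000 nM, again only a limit.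

The three measured compounds share one core and differ only in the group carried on the carbonyl carbon of the amide. Compound 2 therefore has no number of its own to stand on; its result is a limit. The whole set tells the same story: the limit of > 100000 nM in this assay, at which 3 of the 3 values shown sit. Within the data shown here, with no numbers, no step between measured compounds can be sized, and nothing in this set shows that changing the group on that carbonyl carbon moves the read-out at all.

Compound 4 `COc1ccc(C(=O)Nc2cc(Sc3ncn[nH]3)c(O)c3ccccc23)cc1` differs from compound 2 in one place: 4-methoxyphenyl in place of naphthalen-2-yl on a carbonyl carbon. Since three different groups in that position have all left the read-out at the limit, the expected step of a number no higher from compound 2 to compound 4 (the limit leaves the size open) is none beyond the scatter. Compound 4 is expected to give about 100000 nM, within a range from 30000 nM to 500000 nM, most probably reported again as a limit.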

Compound 4, half-maximal inhibitory concentration: > 100000 nM
Compound 4: only a limit was reported; the forecaster's own chance of this, stated with the estimate: 80%; the middle value lies on the limit itself.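

In this assay compound 4 gives > 100000 nM and this is again a limit, not a number. Compound 2 also stands at a limit, so no step can be read between compound 2 and compound 4, and all the compounds shown share one result: the limit of > 100000 nM in this assay, at which 4 of the 4 values shown sit.

The compounds shown leave open whether any group on the carbonyl carbon of the amide can move the read-out at all.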